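Swapping Fluoro for Methyl in a Receptor Binding Series

A few compounds are considered here, and "the series" means these few. Any claim that something is new, unique, unknown or untested is made for them only; others in the source may bear on it.

Of the compounds shown here, two from this study have been measured so far. Compound 1 `CC1CCN(c2c(S(=O)(=O)c3ccc(Cl)cc3)cnc3cc(Cl)ccc23)CC1` was tested in an assay on isolated protein for displacement of a labelled ligand from metabotropic glutamate receptor 5 (Homo sapiens), with a stated time of 60 min, tested at 1 uM (a higher number here means more inhibition at the concentration tested (going by the name of the read-out), a lower number less inhibition), and gives 91%. Compound 2 `Cc1ccc2ncc(S(=O)(=O)c3ccc(F)cc3)c(N3CCC(C)CC3)c2c1` shares the same overall build, and in this assay compound 2 gives 90%. On these two numbers compound 2 sits alongside compound 1, the gap between them lying within the usual scatter of repeated measurements, so the two read as equal in practice.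

The next compound, compound 3 `Cc1ccc(S(=O)(=O)c2cnc3ccc(C)cc3c2N2CCC(C)CC2)cc1`, differs from compound 2 in one place: methyl in place of fluoro on an aromatic carbon. Both groups are small, neither adds a ring, a donor or an acceptor, and no charge changes hands. For the measured compounds named here, no measured pair in this set shows what such a swap does, so the expectation rests on the two numbers already in hand, both of which are high. The expected step from compound 2 to compound 3 is therefore small, of the size a number 2 percentage points lower from compound 2 to compound 3 (within the scatter), and stays within the scatter. Compound 3 is expected to give 88% in this assay, most likely between 75% and 97%.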

Compound 3, a percentage reported as inhibition, at one concentration (the size of the read-out at that concentration, not a potency): 82%
Compound 3: middle estimate off by 6 percentage points, on the high side; low and high end bracket the measured number.
By their numbers in this assay, from the lowest: compounds 3, 2 and 1 (each within the scatter of the next).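

For the compounds shown here, compound 2 and compound 3 form the first pair in this assay that differs in one place, the group para to a large group on the six-membered aromatic ring of carbon only, and the change from 4-fluorophenyl to 4-methylphenyl reads as a number 8 percentage points lower from compound 2 to compound 3 (within the scatter) at this one tested concentration. The two earlier numbers could not show this, as compound 1 and compound 2 differ in more than one place, whereas this pair isolates a single swap, and at this position fluoro and methyl read as equal in practice. What lies behind this cannot be said, as no measurement bearing on the result is available here.

Among the compounds shown, only fluoro and methyl stand at this position, so it remains open whether a group of another kind, such as methoxy, an amine or a carboxylic acid, would give a number in the same range in this assay. Also open, on these data alone, is how far apart the two compounds would stand in a full potency measurement, as a read-out at one concentration gives the size of the inhibition there and not a potency.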